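The source may report more compounds than this note shows. Statements on the series, on what has been measured and on what is new or still open speak of the compounds shown alone.

Measured so far:
- compound 1, `COc1ccc(-c2cc3ccccc3nc2/C=C/C(=O)c2ccc([N+](=O)[O-])cc2)cc1`, in a functional assay on H184B5F5/M10 cells (Homo sapiens) for antiproliferative activity, read by XTT assay, with a stated time of 72 h; on this read-out higher numbers stand for weaker inhibition and lower numbers for stronger inhibition: 6100 nM
- compound 2, `COc1ccc(-c2cc3ccccc3nc2/C=C/C(=O)c2ccccn2)cc1`, in this assay: 4140 nM

Compound 1 holds the highest of the two numbers; the nearest is compound 2, and a 1.5-fold lower number from compound 1 to compound 2 (0.17 log units; within the scatter) sits within the scatter, so the two cannot be ordered on these data.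

Compound 3, `COc1ccc(-c2cc3ccccc3nc2/C=C/C(=O)c2c[nH]c3ccccc23)cc1`, awaits measurement. It differs from compound 1 in one place: 1H-indol-3-yl in place of 4-nitrophenyl on a carbonyl carbon. Going by the values given here, the only measured step that bears on this is the one from compound 1 to compound 2, which also exchanged the group on the carbonyl carbon and stayed within the scatter. Among the compounds with values here, no other exchange at this position has been measured, and the indole itself has no precedent. On that basis a step of a 1.2-fold lower number from compound 1 to compound 3 (0.09 log units; within the scatter) is expected, not beyond the scatter. Compound 3 is accordingly estimated at 5000 nM, with the likely range running from 2000 nM to 13000 nM.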

Compound 3, half-maximal inhibitory concentration: > 10000 nM
Compound 3 gave a limit, no number (the forecaster's own chance of this, stated with the estimate: 5%); middle value at least 2.0-fold (0.30 log units) away from the limit.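

Compound 3 gives a limit of the assay, not a number: the limit of > 10000 nM in this assay, at which 1 of the 3 values shown sits.

Going by these compounds alone, with 1H-indol-3-yl in place of pyridin-2-yl, the result is an at least 2.4-fold higher number from compound 2 to compound 3 (0.38 log units; beyond the scatter), the first step at this position to clear the scatter, so the group on the carbonyl carbon can shift the read-out in this assay. With 1H-indol-3-yl in place of 4-nitrophenyl, the result is an at least 1.6-fold higher number from compound 1 to compound 3 (0.21 log units; that floor lies within the scatter); that floor lies within the scatter, so this pair stays unordered and the limit gives no true size for the step.

Open, as far as these compounds go, is how far the true value of compound 3 lies past the limit. Also open, from the compounds shown here alone, is whether the shift follows the hydrogen-bond donor of 1H-indol-3-yl or its two-ring shape, which a 1-methylindol-3-yl or a plain phenyl group on the same carbonyl carbon would help separate.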